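Lengthening the Methyl Group on Compound 1's Thiophene

The source may report more compounds than this note shows. Statements on the series, on what has been measured and on what is new or still open speak of the compounds shown alone.

Measured compounds:
- compound 1 `Cc1ccsc1CN[C@@H]1C[C@H]2C[C@@H]([C@H]1C)C2(C)C`: 10000 nM
- compound 2 `C[C@H]1[C@H](NCc2cncs2)C[C@H]2C[C@@H]1C2(C)C`: > 100000 nM
- compound 3 `Cc1ccc(CN[C@@H]2C[C@H]3C[C@@H]([C@H]2C)C3(C)C)s1`: 780 nM

In an ADME assay on MDCK cells (Canis lupus familiaris) for cytotoxicity, read by microscopy, with a stated time of 48 h (a higher number here means that more compound is tolerated, a lower number that less compound is tolerated), compound 1 gives 10000 nM, the highest of the two plain numbers shown. Compound 2 gives only a limit of the assay, > 100000 nM. Compound 3 sits nearest to compound 1, with a 13-fold lower number from compound 1 to compound 3 (1.11 log units; beyond the scatter). Compound 4 `CCCc1ccsc1CN[C@@H]1C[C@H]2C[C@@H]([C@H]1C)C2(C)C` differs from compound 1 by ethyl in place of hydrogen on a saturated chain carbon bound to an aromatic carbon.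

Neither measured step mirrors this change. Swapping the ring itself gave an at least 10-fold higher number from compound 1 to compound 2 (1.00 log units; beyond the scatter), and shifting the methyl to another place on the ring gave a 13-fold lower number from compound 1 to compound 3 (1.11 log units; beyond the scatter); both are large, but both alter the ring rather than extend a chain on it. Nothing measured here shows what adding ethyl does. With no guide, a step close to compound 1 is expected, perhaps slightly downward, within a broad range. Compound 4 is therefore estimated at 4000 nM, between 1000 nM and 16000 nM, which is expected to mean a 2.5-fold lower number from compound 1 to compound 4 (0.40 log units; beyond the scatter).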

Compound 4, minimum cytotoxic concentration: 50000 nM
Estimate against measurement, compound 4: 13-fold (1.10 log units) below; the measured number lies above the stated range.
By their numbers in this assay, from the lowest: compound 3; then compound 1; then compound 4. At a limit, above all of these: compound 2.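

In this assay, going from methyl to propyl on the thiophene brings a 5.0-fold higher number from compound 1 to compound 4 (0.70 log units; beyond the scatter), so more compound is tolerated with the longer chain. The earlier steps shown here swapped the ring or moved the methyl, and the step of a 13-fold lower number from compound 1 to compound 3 (1.11 log units; beyond the scatter) ran downward; this one shows that changing only the chain, with the ring and the attachment kept, also moves the number beyond the scatter, and upward. Compound 2 alone stands at a limit of the assay, not at a number: the limit of > 100000 nM in this assay, at which 1 of the 4 values shown sits.

On these data alone, whether the number keeps rising with a longer chain such as butyl, or peaks at propyl, stays open. Also open, as far as these compounds go, is whether a chain carrying oxygen, such as hydroxymethyl, or an amine in place of the propyl would move the number the same way.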